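A few compounds are considered here, and "the series" means these few. Any claim that something is new, unique, unknown or untested is made for them only; others in the source may bear on it.

Compound 1, `COc1ccc2c(Cn3ccnc3)c(-c3ccc(F)cc3)[nH]c2c1`, gives > 1000000 nM in an ADME assay on MCF7 cells (Homo sapiens) for cytotoxicity, read by MTT assay, with a stated time of 48 h (a higher number here means a weaker inhibitor, a lower number a stronger inhibitor), which is a limit of the assay and not a number.
Compound 2, `COc1ccc2c(Cn3ccnc3)c(-c3ccc(Cl)cc3)[nH]c2c1`, gives > 1000000 nM in this assay, again a limit.
Compound 3, `Fc1ccc(-c2[nH]c3cc(F)ccc3c2Cn2cncn2)cc1`, gives > 1000000 nM in this assay, also a limit.

Compound 1 and compound 2 differ by one change, (chloro in place of fluoro on an aromatic carbon). Both sit at the limit of > 1000000 nM in this assay, at which 3 of the 3 values shown sit, so the step that the two limits leave unreadable from compound 1 to compound 2 cannot be read. How the core of compound 3 differs from the core of compound 1 is not broken down here.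

Compound 4, `Fc1ccc(-c2[nH]c3cc(Cl)ccc3c2Cn2cncn2)cc1`, is not yet measured. It differs from compound 3 by chloro in place of fluoro on an aromatic carbon. This is the same kind of change as from compound 1 to compound 2, but the surroundings differ: there the carbon was para to a large group, here it is part of a fused or bridged system of two rings, meta to a fused ring and para to a fused ring.

Because compound 3 stands at the limit of > 1000000 nM in this assay, at which 3 of the 3 values shown sit, the step that the limit leaves unreadable from compound 3 to compound 4 is expected to be small or unreadable. Compound 4 is therefore estimated at 2000000 nM in this assay, most likely reported only as a limit.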

Compound 4, half-maximal inhibitory concentration: 625000 nM
For compound 4 the middle estimate is 3.2-fold (0.51 log units) above the measured one, within the range that was stated.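

With chloro in place of fluoro on an aromatic carbon of the fused system, this assay shows an at least 1.6-fold lower number from compound 3 to compound 4 (0.20 log units; that floor lies within the scatter). Going by these compounds, this shows that compound 4 gives a real number where compound 3 gives only a limit of the assay, but the true size of the step stays unknown, and the smallest size it could have does not clear the usual scatter, so it cannot be called a firm gain. The same change from compound 1 to compound 2 cannot be read, so nothing here shows whether the change carries from one core to the other, and the obstacle is the limit those compounds share: the limit of > 1000000 nM in this assay, at which 3 of the 4 values shown sit.

The compounds shown leave open whether a group of a different kind on that same aromatic carbon, such as an amine or a carboxylic acid, would move the number further than chloro does. They also leave open what a longer chain there would do, on either core.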